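Two Amide Chains on Two Cores in HeLa Cells

This account rests on a few compounds, and the source may have more. Where it says the series, first, only, none or still open, it means among the compounds named here.

Compound 1 `CC(C)=CC(=O)Nc1cccc(Oc2nc(Nc3ccn(C)n3)nc3c2CSCC3)c1` carries a shared core with an amide chain on one side. In a functional assay on HeLa cells (Homo sapiens) for antiproliferative activity, read by MTT assay, with a stated time of 72 h (on this read-out lower numbers stand for stronger inhibition and higher numbers for weaker inhibition), compound 1 gives a limit of > 50000 nM, so no number is known for it. Compound 2 `CC(C)/C=C/C(=O)Nc1cccc(Oc2nc(Nc3ccn(C)n3)nc3c2CSCC3)c1` differs from compound 1 by 3-methylbut-1-en-1-yl in place of 2-methylprop-1-en-1-yl on a carbonyl carbon, and in this assay compound 2 gives 40100 nM. This is an at least 1.2-fold lower number from compound 1 to compound 2 (0.09 log units; that floor lies within the scatter). That step has only a floor, which comes from compound 1 sitting at the limit of > 50000 nM in this assay, at which 1 of the 3 values shown sits.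

Compound 3 `CC(C)=CC(=O)Nc1cccc(Oc2nc(Nc3cccc(C#N)c3)nc3c2CSCC3)c1` keeps the chain of compound 1 but its core differs by 3-cyanophenyl in place of 1-methyl-1H-pyrazol-3-yl on a nitrogen on an aromatic ring. In this assay compound 3 gives 29200 nM, which is an at least 1.7-fold lower number from compound 1 to compound 3 (0.23 log units; that floor lies within the scatter). The numbers for compound 2 and compound 3 lie within the usual scatter of each other, so neither can be placed ahead of the other.

Compound 4 `CC(C)/C=C/C(=O)Nc1cccc(Oc2nc(Nc3cccc(C#N)c3)nc3c2CSCC3)c1` has not yet been measured. It differs from compound 3 by 3-methylbut-1-en-1-yl in place of 2-methylprop-1-en-1-yl on a carbonyl carbon, and the place where the change sits is described in the same words as for the change from compound 1 to compound 2, so it is the same change, made on the core of compound 3. The earlier step gives only a floor, so the expected step from compound 3 to compound 4 is set at a 1.5-fold lower number from compound 3 to compound 4 (0.16 log units; within the scatter), a small lowering that rests on compound 1 and compound 2 through an at least 1.2-fold lower number from compound 1 to compound 2 (0.09 log units; that floor lies within the scatter). On that basis compound 4 is estimated at 20000 nM, with a likely range from 8000 nM to 45000 nM.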

Compound 4, half-maximal inhibitory concentration: 22800 nM
Estimate against measurement, compound 4: 1.1-fold (0.06 log units) below; the range from low to high includes it.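

In this assay, putting 3-methylbut-1-en-1-yl in place of 2-methylprop-1-en-1-yl on the carbonyl carbon gives a 1.3-fold lower number from compound 3 to compound 4 (0.11 log units; within the scatter), and putting 3-cyanophenyl in place of 1-methyl-1H-pyrazol-3-yl on the nitrogen gives a 1.8-fold lower number from compound 2 to compound 4 (0.25 log units; within the scatter), so neither measured step stands clear of the usual scatter of repeat measurements. The chain change is therefore compatible with carrying over from one core to the other, but this does not show that it carries over, or even that it has a real effect on either core: the same change on two cores in this assay, an at least 1.2-fold lower number (0.09 log units; that floor lies within the scatter) from compound 1 to compound 2 and a 1.3-fold lower number (0.11 log units; within the scatter) from compound 3 to compound 4; the limit leaves it open whether they differ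

The same caution applies to the change on the nitrogen, whose two readings also cannot be told apart or shown to be real effects: the same change on two cores in this assay, an at least 1.7-fold lower number (0.23 log units; that floor lies within the scatter) from compound 1 to compound 3 and a 1.8-fold lower number (0.25 log units; within the scatter) from compound 2 to compound 4; the limit leaves it open whether they differ

The compounds shown leave open whether any change at these two places can move the number beyond the scatter, for example a longer chain or a chain ending in a dimethylamino group on the carbonyl carbon. They also leave open whether a phenyl group carrying a carboxylic acid on the nitrogen would behave the same way on both sides of the series.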